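The source may report more compounds than this note shows. Statements on the series, on what has been measured and on what is new or still open speak of the compounds shown alone.

Working notes on the series. In a functional assay on the whole organism with Rattus norvegicus as the target (on this read-out higher numbers stand for an effect only at larger amounts of compound and lower numbers for an effect already at smaller amounts), compound 1 (`CCNCCNC(=O)c1cc(Cl)c(N)cc1OC`) gives > 30 mg/kg, which is a limit and not a number. Compound 2 (`COc1cc(N)c(Cl)cc1C(=O)NCCN(C)C(C)c1ccccc1`) gives 1 mg/kg. Compound 3 (`COc1cc(N)c(Cl)cc1C(=O)NCCN(C)CC1CCCCC1`) gives 3 mg/kg. Going by the values given here, both therefore give a measured number in this assay, with 1-phenylethyl and cyclohexylmethyl respectively replaced here by plain wording: compound 2 carries the first group on an amine nitrogen and compound 3 the second. Cyclohexylmethyl in place of 1-phenylethyl on an amine nitrogen gives a 3.0-fold higher number from compound 2 to compound 3 (0.48 log units; beyond the scatter), a modest step beyond the scatter.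

Compound 4 (`CCN(CCNC(=O)c1cc(Cl)c(N)cc1OC)Cc1ccccc1Cl`) differs from compound 1 by 2-chlorobenzyl in place of hydrogen on an amine nitrogen. Among the compounds with values here, no measured step covers this exact change, and no measured compound carries 2-chlorobenzyl. The closest guide is the pair of compound 2 at 1 mg/kg and compound 3 at 3 mg/kg, whose separation of a 3.0-fold higher number from compound 2 to compound 3 (0.48 log units; beyond the scatter) also sets how much the choice of group may matter. A clear move towards lower numbers is therefore expected in this assay, though its size is uncertain given that the starting point is only a limit. The expected change is an at least 15-fold lower number from compound 1 to compound 4 (1.17 log units; beyond the scatter). For compound 4 the estimated value is 2 mg/kg, with an expected range from 0.5 mg/kg to 10 mg/kg.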

Compound 4, dose for half-maximal effect: 10 mg/kg
Compound 4: the middle estimate sits 5.0-fold (0.70 log units) below what was measured; the measured number falls inside the stated range.
By their numbers in this assay, from the lowest: compound 2; then compound 3; then compound 4. At a limit, above all of these: compound 1.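

In this assay, going by these compounds alone, the change from hydrogen to 2-chlorobenzyl on an amine nitrogen gives an at least 3.0-fold lower number from compound 1 to compound 4 (0.47 log units; beyond the scatter), the first step read from an unsubstituted position on this nitrogen. Within the data shown here, it shows that this one change is enough to move the series from a limit to a measured number, whereas the earlier step compared only two groups already carried on an amine nitrogen. As far as these compounds go, the true size of the step stays unknown because compound 1 gives a limit and not a number, so the step is only a bound: the limit of > 30 mg/kg in this assay, at which 1 of the 4 values shown sits.

Among these compounds, compound 4 differs from compound 2 and from compound 3 in more than one place, so no step between compound 4 and either of them can be read, and the effect of 2-chlorobenzyl cannot be ranked against that of 1-phenylethyl or cyclohexylmethyl. The compounds shown also leave open whether the chlorine contributes to the step or whether a plain benzyl, or a simple chain such as butyl, on the same nitrogen would give a similar number.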